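A few compounds are considered here, and "the series" means these few. Any claim that something is new, unique, unknown or untested is made for them only; others in the source may bear on it.

Measured so far in a functional assay on MIA PaCa-2 cells (Homo sapiens) for cytotoxicity, read by WST assay, with a stated time of 48 h; a higher number here means a weaker inhibitor, a lower number a stronger inhibitor:
Compound 1 `N#C/C(=C\c1cn(Cc2ccc(Cl)cc2)c2ccccc12)C(=O)c1c[nH]c2ccccc12` gives a limit, > 50000 nM.
Compound 2 `COc1ccc2c(/C=C(\C#N)C(=O)c3c[nH]c4cc(OC)ccc34)c[nH]c2c1` gives a limit, > 50000 nM.
Compound 3 `N#C/C(=C\c1c[nH]c2ccccc12)C(=O)c1c[nH]c2ccccc12` gives 36800 nM.

Within the data shown here, compound 3 holds the only number in this set; the two other values are limits: the limit of > 50000 nM in this assay, at which 2 of the 3 values shown sit. Among the measured compounds shown here, the one counted step, an at least 1.3-fold lower number from compound 1 to compound 3 (0.13 log units; that floor lies within the scatter), hydrogen in place of 4-chlorobenzyl on an aromatic nitrogen, runs from a limit to a number and is itself only a floor.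

Compound 4 `COc1ccc2c(/C=C(\C#N)C(=O)c3c[nH]c4ccccc34)c[nH]c2c1` differs from compound 3 by methoxy in place of hydrogen on an aromatic carbon. For the measured compounds named here, no measured step matches this change. Compound 2, which also carries methoxy, sits at a limit, and compound 3 is already weak. The expected step, a 1.1-fold higher number from compound 3 to compound 4 (0.04 log units; within the scatter), is none beyond the scatter. Compound 4 is therefore estimated at 40000 nM, within 15000 nM to 100000 nM, with a fair chance that only a limit is reported.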

Compound 4, half-maximal inhibitory concentration: > 50000 nM
Compound 4: a limit, no number (the forecaster's own chance of this, stated with the estimate: 50%); at least 1.2-fold (0.09 log units) between middle value and limit.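

In this assay, methoxy in place of hydrogen on an aromatic carbon of the six-membered ring gives an at least 1.3-fold higher number from compound 3 to compound 4 (0.13 log units; that floor lies within the scatter). Among these compounds, this is the first readable outcome for this change on the shared core: no lower number appears, and the floor does not separate the change from no effect. The series now gathers at one limit: the limit of > 50000 nM in this assay, at which 3 of the 4 values shown sit.

The step between compound 2 and compound 4 cannot be read, since both values are limits. Open, on these data alone, is whether an amine or a carboxylic acid in this place moves the number away from that of compound 3, 36800 nM.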